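This account rests on a few compounds, and the source may have more. Where it says the series, first, only, none or still open, it means among the compounds named here.

Series notes. Every member carries the same nitrile-bearing aniline on the shared core. Going by the values given here, compound 1 `Cc1ccc(C(=O)Nc2ccc(C#N)cc2)c(O)c1` is the only one with a numerical reading: in a functional assay on HL-60 cells (Homo sapiens) for cytotoxicity, read by luminescence and CellTiter-Glo, with a stated time of 3 days (a higher number here means a weaker inhibitor, a lower number a stronger inhibitor), compound 1 gives 2420 nM. Compound 2 `N#Cc1ccc(NC(=O)c2ccc[nH]c2=O)cc1` returns only a limit in this assay, namely > 10000 nM. Compound 3 `N#Cc1ccc(Nc2n[nH]c3ccccc23)cc1` likewise sits at a limit in this assay, namely > 10000 nM. Compound 1 therefore stands alone with a number, while the other two readings are simply the limit of this assay (the limit of > 10000 nM in this assay, at which 2 of the 3 values shown sit). Among the compounds with values here, no pair of measured compounds differs in a single place, so no measured step can be drawn from what is in hand.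

Compound 4 `N#Cc1ccc(NC(=O)c2ccccc2O)cc1` is the next case, differing from compound 1 by hydrogen in place of methyl on an aromatic carbon. The change removes only a methyl from the core of compound 1 and adds nothing. For this assay the step is expected to be small, a modest loss at most or nothing beyond the scatter, a 1.7-fold higher number from compound 1 to compound 4 (0.22 log units; within the scatter). Compound 4 is thus expected to give 4000 nM in this assay, with a range from 1500 nM to 12000 nM.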

Compound 4, half-maximal inhibitory concentration: 4620 nM
Beside the measured number, compound 4's estimate is 1.2-fold (0.06 log units) below it, within the range that was stated.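

In this assay, going by these compounds alone, hydrogen in place of methyl on an aromatic carbon gives a 1.9-fold higher number from compound 1 to compound 4 (0.28 log units; within the scatter), the only step that can be read so far. At this place, meta to a hydroxy group and para to a large group, the pair therefore shows that the numerical reading does not depend on the methyl, and the two compounds cannot be ranked against each other. Nothing in hand bears on a cause for this outcome.

On these data alone, the pair tests only methyl and hydrogen, so it remains open whether an amine, a carboxylic acid or a longer chain such as ethyl at the same place would move the number beyond the scatter. Within the data shown here, the role of the hydroxy group also stays open, as no measured pair changes that group alone.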